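This account rests on a few compounds, and the source may have more. Where it says the series, first, only, none or still open, it means among the compounds named here.

Measured compounds:
compound 1 `CCn1c(C(=O)NCCCN(C)C)ccc1C(CC)(CC)c1ccc(OCCC(O)(CC)CC)c(C)c1`, in an assay on cells for agonist activity at vitamin D3 receptor (Homo sapiens), with a stated time of 96 h (on this read-out lower numbers stand for an effect already at smaller amounts and higher numbers for an effect only at larger amounts of compound), compound 1 gives 5 nM
compound 2 `CCOC(=O)CN(C)C(=O)c1ccc(C(CC)(CC)c2ccc(OCCC(O)(CC)CC)c(C)c2)n1CC`, in this assay compound 2 gives 520 nM

Among the compounds with values here, compound 2 stands at the highest number of the two measured in this assay; its nearest neighbour is compound 1, and the single measured step, a 100-fold higher number from compound 1 to compound 2 (2.02 log units; beyond the scatter), separates them. That step exchanges the amide substituent on the carbonyl carbon of the shared core and is the only one that bears on the change now in question.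

Compound 3 `CCn1c(C(=O)NC(C)CO)ccc1C(CC)(CC)c1ccc(OCCC(O)(CC)CC)c(C)c1` is not yet measured in this assay. It differs from compound 2 as follows: (1-(hydroxymethyl)ethyl)amino in place of ((ethoxycarbonyl)methyl)(methyl)amino on a carbonyl carbon. The group entering carries an amide hydrogen again, as the amide of compound 1 does, while the group leaving is the one that accompanied the large rise from compound 1 to compound 2. Within the data shown here, on that basis a return towards the number of compound 1 is expected, though the new group is neither the one of compound 1 nor the one of compound 2, so the full size of the measured step is not assumed.

For compound 3 in this assay the expected result is 25 nM, within 5 nM to 130 nM, which corresponds to an estimated step of a 21-fold lower number from compound 2 to compound 3 (1.32 log units; beyond the scatter).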

Compound 3, half-maximal effective concentration: 96 nM
The estimate for compound 3 lay 3.8-fold (0.58 log units) below the measured number; measured number inside the range.
By their numbers in this assay, from the lowest: compound 1; then compound 3; then compound 2.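

In this assay, putting (1-(hydroxymethyl)ethyl)amino on the carbonyl carbon in place of ((ethoxycarbonyl)methyl)(methyl)amino gives only a partial return, with a 5.4-fold lower number from compound 2 to compound 3 (0.73 log units; beyond the scatter) read as modest. Against the other amide, a 19-fold higher number from compound 1 to compound 3 (1.28 log units; beyond the scatter) is large, so the amide hydrogen, present in both compound 1 and compound 3, does not by itself bring the number back to that of compound 1. At this position the rest of the substituent also goes with the read-out: 3-(dimethylamino)propyl and 1-(hydroxymethyl)ethyl on the amide-type nitrogen stand apart, and the order of the three groups is now fixed in this assay only. No measurement at hand bears on why the numbers move in this way.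

Still open, on these data alone, is whether the dimethylamino group or the length of the chain goes with the lowest number, a question that a 3-hydroxypropyl or a 2-(dimethylamino)ethyl group on the amide-type nitrogen would separate. For compound 2, the methyl on the amide nitrogen and the ethyl ester change together, so the same chain without that methyl, or with a carboxylic acid in place of the ester, would be needed to tell their shares apart.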